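The source may report more compounds than this note shows. Statements on the series, on what has been measured and on what is new or still open speak of the compounds shown alone.

In a physicochemical assay for solubility, at pH 7.4 (a higher number here means a more soluble compound, a lower number a less soluble compound), compound 1 `O=P(O)(O)OCc1nc(Nc2ccc(C(F)(F)F)cc2)c2ccc(-c3ncccc3C(F)(F)F)cc2n1` gives > 138 ug/mL as its reading, and this reading is a limit of the assay, not a number. Compound 2 `OCCc1nc(Nc2ccc(C(F)(F)F)cc2)c2ccc(-c3ncccc3C(F)(F)F)cc2n1` reads 0.02 ug/mL in this assay on the same scale. Compound 3 `OCCCc1nc(Nc2ccc(C(F)(F)F)cc2)c2ccc(-c3ncccc3C(F)(F)F)cc2n1` reads 0.06 ug/mL and so holds the higher of the two actual numbers.

Compound 4 `FC(F)(F)c1ccc(Nc2nc(CN3CCCC3)nc3cc(-c4ncccc4C(F)(F)F)ccc23)cc1` differs from compound 3 by pyrrolidin-1-yl in place of 2-hydroxyethyl on a saturated chain carbon bound to an aromatic carbon in that one place. The same difference, cut one bond further out, reads 3-hydroxypropyl to (pyrrolidin-1-yl)methyl.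

Within the data shown here, three measured steps bear on this place. The nearest in kind is a 3.0-fold higher number from compound 2 to compound 3 (0.48 log units; beyond the scatter) along the chain, and it is modest. The other two, an at least 6900-fold lower number from compound 1 to compound 2 (3.83 log units; beyond the scatter) and an at least 2300-fold lower number from compound 1 to compound 3 (3.36 log units; beyond the scatter) in the same place, are large, but both start from a limit and both remove the phosphorus-bearing group, which compound 3 does not carry. Among the measured compounds shown here, no measured step brings a ring onto this chain carbon, so the expectation leans on the modest step alone. A modest rise in this assay is therefore expected, though a fall cannot be ruled out. The expected move is a 3.3-fold higher number from compound 3 to compound 4 (0.52 log units; beyond the scatter) as a rough estimate. In this assay compound 4 is estimated at 0.2 ug/mL with an expected range from 0.03 ug/mL to 3 ug/mL for repeated readings.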

Compound 4, solubility: 25 ug/mL
The estimate for compound 4 lay 130-fold (2.10 log units) below the measured number; the whole stated range lies below it.
By their numbers in this assay, from the lowest: compound 2; then compound 3; then compound 4. At a limit, above all of these: compound 1.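

In this assay, (pyrrolidin-1-yl)methyl in place of 3-hydroxypropyl gives a 420-fold higher number from compound 3 to compound 4 (2.62 log units; beyond the scatter), and the comparison with the shorter hydroxy chain gives a 1300-fold higher number from compound 2 to compound 4 (3.10 log units; beyond the scatter). Among these compounds, until now the only large steps at this saturated chain carbon involved the phosphorus-bearing group of compound 1, whereas compound 4, at 25 ug/mL, shows that a group without phosphorus, carrying a five-membered ring with one nitrogen, can also move this assay by a large amount from the hydroxy chains. The remaining step, an at least 5.5-fold lower number from compound 1 to compound 4 (0.74 log units; beyond the scatter), starts from a reading that is a limit and not a number, so the true size of that gap stays unknown: the limit of > 138 ug/mL in this assay, at which 1 of the 4 values shown sits.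

The compounds shown do not separate the contribution of the ring from that of the nitrogen, which an open-chain amine such as dimethylamino or an all-carbon cyclopentyl group in the same place would address. They also leave open whether a morpholine ring, a carboxylic acid or a longer chain between the pyrrolidine and the shared core would give a similar reading.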